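Turning a cyclopropyl sulfoximine back into a fluorinated diol

The compounds below may be only part of what the source reports. "The series", "measured", "known", "first", "only" and "open" are said of these compounds alone.

Of the compounds shown here, three sharing one core have been tested in an assay on isolated protein for inhibition of glucokinase regulatory protein (Homo sapiens), read by AlphaScreen, with stated times of 20 min and 4 h; a higher number here means a weaker inhibitor, a lower number a stronger inhibitor. Compound 1 `CC#C[C@H]1CN(S(=O)(=O)c2ccc(N)nc2)CCN1c1ccc([C@@](O)(CO)C(F)(F)F)cc1` gives 6 nM. Compound 2 `CC#C[C@H]1CN(S(=O)(=O)c2ccc(N)nc2)CCN1c1ccc(S(=O)(=NC)C(F)(F)F)cc1` gives 266 nM, and compound 3 `CC#C[C@H]1CN(S(=O)(=O)c2ccc(N)nc2)CCN1c1ccc(S(=N)(=O)C2CC2)cc1` gives 256 nM. Compound 3 thus stands second highest of the three numbers, close to compound 2 and far from compound 1, which is the strongest inhibitor here, as shown by a 44-fold higher number from compound 1 to compound 2 (1.65 log units; beyond the scatter) and a 43-fold higher number from compound 1 to compound 3 (1.63 log units; beyond the scatter). Between compounds 2 and 3 the step is a 1.0-fold lower number from compound 2 to compound 3 (0.02 log units; within the scatter).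

Compound 4 `CC#C[C@H]1CN(S(=O)(=O)c2ccc(N)nc2)CCN1c1ccc([C@](O)(CO)C(F)(F)F)cc1` has not been measured. Compared with compound 3, the change is a group of 8 heavy atoms (3 carbon, 2 oxygen, 3 fluorine; no ring) in place of a group of 6 heavy atoms (3 carbon, 1 nitrogen, 1 oxygen, 1 sulfur; one three-membered non-aromatic ring of carbon only), on an aromatic carbon: the entering group is 1,2-dihydroxy-1-(trifluoromethyl)ethyl, with one defined stereocentre, placed on an aromatic carbon of a six-membered aromatic ring of carbon only, para to a large group. This is the same group that compound 1 carries, but with the opposite configuration at that stereocentre. The step from compound 1 to compound 3 was large, so the reverse change should lower the number; nothing in these data tells how much the configuration matters. Compound 4 is therefore expected to be a clearly stronger inhibitor than compound 3, with an expected step of a 6.4-fold lower number from compound 3 to compound 4 (0.81 log units; beyond the scatter), giving an estimate of 40 nM within 8 nM to 250 nM.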

Compound 4, half-maximal inhibitory concentration: 28 nM
Compound 4: the middle estimate sits 1.4-fold (0.15 log units) above what was measured, within the range that was stated.
By their numbers in this assay, from the lowest: compound 1; then compound 4; then compounds 3 and 2 (each within the scatter of the next).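

In this assay, the 1,2-dihydroxy-1-(trifluoromethyl)ethyl group beats both sulfoximine groups even in the configuration not tested before, with a 9.1-fold lower number from compound 3 to compound 4 (0.96 log units; beyond the scatter) and a 9.5-fold lower number from compound 2 to compound 4 (0.98 log units; beyond the scatter). What is new is that the configuration at this single stereocentre matters as well, with a 4.7-fold higher number from compound 1 to compound 4 (0.67 log units; beyond the scatter), and this step can be pinned on that stereocentre alone, for a simple reason: the fact that compounds 1 and 4 differ only in the configuration as drawn Both configurations of the diol group give lower numbers than the two sulfoximines, so in this small set, reversing the stereocentre weakens inhibition without removing the gain over those groups.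

The compounds shown do not separate the parts of the diol group: a 1-hydroxy-1-(trifluoromethyl)ethyl group, lacking the hydroxymethyl arm, or a version with methyl in place of trifluoromethyl, would help show which part carries the gain. From the compounds shown here alone, it also remains open whether the same configuration is preferred on a core other than the shared one, or with a carboxylic acid or an amine in place of the primary alcohol.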